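A few compounds are considered here, and "the series" means these few. Any claim that something is new, unique, unknown or untested is made for them only; others in the source may bear on it.

Measured compounds in the series:

- compound 1 `Cc1cc(C#N)cc(C)c1Oc1nc(Nc2ccc(C#N)cc2)ncc1-c1ccc(N)cc1`: 310 nM
- compound 2 `Cc1cc(C#N)cc(C)c1Oc1nc(Nc2ccc(C#N)cc2)ncc1-c1cccs1`: 6430 nM
- compound 3 `Cc1cc(C#N)cc(C)c1Oc1nc(Nc2ccc(C#N)cc2)ncc1-c1ccc(F)cc1`: 42700 nM

Across these three, compound 3 gives the highest number in an ADME assay on MT4 cells (Homo sapiens) for cytotoxicity, read by MTT assay, with a stated time of 5 days; a higher number here means that more compound is tolerated, a lower number that less compound is tolerated; the nearest is compound 2, from which a 6.6-fold higher number from compound 2 to compound 3 (0.82 log units; beyond the scatter), and the furthest is compound 1, from which a 140-fold higher number from compound 1 to compound 3 (2.14 log units; beyond the scatter). The only position varied is the aromatic carbon carrying the aryl group, and every swap there moved the number beyond the scatter, including a 21-fold higher number from compound 1 to compound 2 (1.32 log units; beyond the scatter).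

Compound 4 `Cc1cc(C#N)cc(C)c1Oc1nc(Nc2ccc(C#N)cc2)ncc1-c1ccc2ccccc2c1` carries the next change at that same position: naphthalen-2-yl in place of 4-fluorophenyl on an aromatic carbon. Within the data shown here, no measured step covers this particular exchange. What bears on it is that each of the three measured steps at this carbon was modest to large, so a step beyond the scatter is the likelier outcome, and since compound 3 already holds the highest number, the room to move is mostly downward. The expectation for this assay is therefore a lower number, of a size between the two shorter measured steps, which is expressed as a 3.6-fold lower number from compound 3 to compound 4 (0.55 log units; beyond the scatter).

The estimate for compound 4 in this assay is 12000 nM, with a range from 3000 nM to 45000 nM.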

Compound 4, half-maximal cytotoxic concentration: 8460 nM
Compound 4: the middle estimate sits 1.4-fold (0.15 log units) above what was measured; measured number inside the range.
By their numbers in this assay, from the lowest: compound 1; then compounds 2 and 4 (each within the scatter of the next); then compound 3.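

In this assay, going from the single ring of 4-fluorophenyl to the two rings of naphthalen-2-yl gives a 5.0-fold lower number from compound 3 to compound 4 (0.70 log units; beyond the scatter), so compound 3 stays alone at the top of the series and the fluoro-bearing aryl group is not matched by a larger all-carbon aryl group at this position. Naphthalen-2-yl and thiophen-2-yl cannot be told apart here, with a 1.3-fold higher number from compound 2 to compound 4 (0.12 log units; within the scatter), while the gap to the amino-bearing aryl group remains wide, at a 27-fold higher number from compound 1 to compound 4 (1.44 log units; beyond the scatter), which leaves compound 1 as the only clear outlier at the low end of the four. Nothing available explains either the drop from compound 3 or the closeness of compound 2 and compound 4.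

On these data alone, whether the low number of compound 1 belongs to the amino group itself stays open, and a dimethylamino, acetamido or hydroxyl group in place of that amino group would bear on it. Equally open, as far as these compounds go, is whether the high number of compound 3 depends on the fluoro group, which unsubstituted phenyl, 4-chlorophenyl or naphthalen-1-yl at the same carbon could test.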